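The source may hold more compounds than are shown below. What is called first, only, known or untested is meant among the compounds shown, and "the series" means these compounds.

Series notes. Compound 1 `NS(=O)(=O)NC(=O)OC[C@H]1O[C@@H](n2ccc(=O)[nH]c2=O)C[C@@H]1O`, compound 2 `O=c1ccn([C@H]2C[C@H](O)[C@@H](CO[Si](c3ccccc3)(c3ccccc3)c3ccccc3)O2)c(=O)[nH]1` and compound 3 `CC(=O)NCC1OC(n2ccc(=O)[nH]c2=O)CC1O` share one core; compound 4 `NCC1OC(n2ccc(=O)[nH]c2=O)CC1O` is the unmeasured member. In an in vitro assay on BL21-DE3 cells for inhibition of Deoxyuridine 5'-triphosphate nucleotidohydrolase, mitochondrial (Homo sapiens) (a lower number here means a stronger inhibitor, a higher number a weaker inhibitor), compound 2 gives 909000 nM. For compound 1 the result in this assay is > 1000000 nM, which is a limit and not a number. For compound 3 the result in this assay is likewise only a limit, > 1000000 nM. Compound 3 therefore stands at the weak end of what has been recorded, with no number of its own, and the picture across the set is the limit of > 1000000 nM in this assay, at which 2 of the 3 values shown sit.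

The change from compound 3 to compound 4 is hydrogen in place of acetyl on an amine nitrogen. Among the compounds with values here, no measured pair shows this change, so there is no recorded step to lean on; the expected step of a number no higher from compound 3 to compound 4 (the limit leaves the size open) is none beyond the scatter, with compound 4 staying close to compound 3 given > 1000000 nM. Compound 4 is estimated at 1000000 nM in this assay, within 400000 nM to 3000000 nM.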

Compound 4, inhibition constant: > 1000000 nM
Compound 4: only a limit was reported; the forecaster's own chance of this, stated with the estimate: 70%; the middle value sits exactly at the limit.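

In this assay compound 3 and compound 4 each carry only a limit, so no step can be read between them. The compounds shown leave open whether hydrogen in place of acetyl on the amine nitrogen changes inhibition at all, and how far either compound lies past its limit.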